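Swapping Trifluoromethyl for Bromo on the Benzoyl Ring

The source may hold more compounds than are shown below. What is called first, only, known or untested is meant among the compounds shown, and "the series" means these compounds.

Measured compounds in an assay on isolated protein for inhibition of aldehyde dehydrogenase 1A1 (Homo sapiens), read by spectrophotometry, tested at 10 uM; on this read-out higher numbers stand for more inhibition at the one concentration tested (going by the name of the read-out) and lower numbers for less inhibition:
compound 1 `Cc1cccc(Cn2c(CN3CCN(C(=O)c4ccc(C(C)C)cc4)CC3)nc3ccccc32)c1`: 67.6%
compound 2 `Cc1cccc(Cn2c(CN3CCN(C(=O)c4cccs4)CC3)nc3ccccc32)c1`: 60.8%
compound 3 `Cc1cccc(Cn2c(CN3CCN(C(=O)c4ccc(C(F)(F)F)cc4)CC3)nc3ccccc32)c1`: 22.9%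

Compound 3 stands lowest of the three in this assay; the steps of a number 44.7 percentage points lower from compound 1 to compound 3 (beyond the scatter) and a number 37.9 percentage points lower from compound 2 to compound 3 (beyond the scatter) both end at it and both lie beyond the scatter, while a number 6.8 percentage points lower from compound 1 to compound 2 (within the scatter) stays within it. Compound 4 `Cc1cccc(Cn2c(CN3CCN(C(=O)c4ccc(Br)cc4)CC3)nc3ccccc32)c1` differs from compound 3 by bromo in place of trifluoromethyl on an aromatic carbon. The step that bears most directly on this change is a number 44.7 percentage points lower from compound 1 to compound 3 (beyond the scatter), where a group at the same aromatic carbon was exchanged and the number fell sharply; a number 37.9 percentage points lower from compound 2 to compound 3 (beyond the scatter) points the same way. Compound 4 is therefore expected to recover part of that loss, with a number 19.1 percentage points higher from compound 3 to compound 4 (beyond the scatter) as an upward step of uncertain size. Compound 4 is estimated at 42%, within 18% to 66%.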

Compound 4, a percentage reported as inhibition, at one concentration (the size of the read-out at that concentration, not a potency): 25.8%
Beside the measured number, compound 4's estimate is 16.2 percentage points above it, within the range that was stated.
By their numbers in this assay, from the lowest: compounds 3 and 4 (each within the scatter of the next); then compounds 2 and 1 (each within the scatter of the next).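

In this assay, bromo on this aromatic carbon, para to a large group, does not separate from trifluoromethyl, with a number 2.9 percentage points higher from compound 3 to compound 4 (within the scatter). The loss against the isopropyl and thiophen-2-yl compounds therefore is not particular to trifluoromethyl, since bromo shows it too, with a number 41.8 percentage points lower from compound 1 to compound 4 (beyond the scatter) and a number 35 percentage points lower from compound 2 to compound 4 (beyond the scatter). Nothing measured here accounts for this shared low level. Still open, from the compounds shown here alone, is where a methoxy group, an amine or a carboxylic acid on the same carbon would fall, whether with isopropyl or with bromo and trifluoromethyl.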